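A few compounds are considered here, and "the series" means these few. Any claim that something is new, unique, unknown or untested is made for them only; others in the source may bear on it.

Measured so far in a functional assay on thoracic aorta (Rattus norvegicus, strain Wistar), with a stated time of 15 min; on this read-out higher numbers stand for an effect only at larger amounts of compound and lower numbers for an effect already at smaller amounts:
compound 1 `CCOc1ccc(F)cc1C(C)NC(=O)NS(=O)(=O)c1ccc(Cl)cc1`: > 300000 nM
compound 2 `COc1ccc(Cl)cc1C(C)NC(=O)NS(=O)(=O)c1ccc(Cl)cc1`: > 300000 nM
compound 3 `COc1ccc(F)cc1C(C)NC(=O)NS(=O)(=O)c1ccc(C)cc1`: > 300000 nM

Compound 3 gives > 300000 nM, which is a limit of the assay and not a number. It has no measured number to be ranked against, since the whole set shares one reference point: the limit of > 300000 nM in this assay, at which 3 of the 3 values shown sit.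

The next compound to be tested, compound 4 `COc1ccc(F)cc1C(C)NC(=O)NS(=O)(=O)c1ccc(Cl)cc1`, differs from compound 3 in a single place, with chloro in place of methyl on an aromatic carbon, so that 4-methylphenyl becomes 4-chlorophenyl: chloro in place of methyl on an aromatic carbon.

Among the compounds with values here, no step between two measured compounds is available as a guide, so the expectation rests on what the nearest structures show. Compound 1 already carries the 4-chlorophenyl group and gives > 300000 nM, a limit. Compound 2 carries this group as well and gives > 300000 nM, again a limit.

The swap is therefore not expected to move this assay beyond the usual scatter in either direction, and another limit is the most likely report. The expected change is a number no higher from compound 3 to compound 4 (the limit leaves the size open). Compound 4 is estimated at 300000 nM, with an expected range from 100000 nM to 600000 nM.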

Compound 4, half-maximal effective concentration: > 300000 nM
Compound 4 gave a limit, no number; the forecaster's own chance of this, stated with the estimate: 75%; the middle value sits exactly at the limit.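

In this assay compound 4 gives > 300000 nM, a limit of the assay and not a number. The steps linking compound 1, compound 2 and compound 3 to compound 4 therefore cannot be read, as all four compounds share one reference point: the limit of > 300000 nM in this assay, at which 4 of the 4 values shown sit.

The compounds shown leave open whether any of these single changes shifts the effect, and by how much.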